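Swapping the group on the amide nitrogen: a clearance estimate

The compounds below may be only part of what the source reports. "The series", "measured", "known", "first", "only" and "open" are said of these compounds alone.

- compound 1 `COc1ccc(NC(=O)[C@H]2CN(C)C[C@@H]2c2ccc(/C=C/C(=O)Nc3ccccc3N)cc2)cc1` gives 54 mL/min/kg
- compound 2 `CN1C[C@H](C(=O)Nc2ccc(C3CC3)cc2)[C@@H](c2ccc(/C=C/C(=O)Nc3ccccc3N)cc2)C1` gives 60 mL/min/kg
- compound 3 `CN1C[C@H](C(=O)Nc2ccc(F)c(Br)c2)[C@@H](c2ccc(/C=C/C(=O)Nc3ccccc3N)cc2)C1` gives 43 mL/min/kg

These numbers come from an in vitro ADME assay on microsomes from liver (Mus musculus) for pharmacokinetics, read by LC-MS, with a stated time of 10 min, tested at 1 uM (on this read-out higher numbers stand for fast clearance and lower numbers for slow clearance), and describe three compounds that share one core. Compound 3, at 43 mL/min/kg on this read-out, lies within the usual scatter of both other compounds, so the three values cannot be told apart.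

Compound 4 `CN1C[C@H](C(=O)Nc2ccc(F)cc2F)[C@@H](c2ccc(/C=C/C(=O)Nc3ccccc3N)cc2)C1` carries 2,4-difluorophenyl in place of 3-bromo-4-fluorophenyl on an amide-type nitrogen, a difference counted as 2,4-difluorophenyl in place of 3-bromo-4-fluorophenyl on an amide-type nitrogen in the structure.

Among the measured compounds shown here, three measured steps bear on this change. Exchanging the group at that same place gave a 1.3-fold lower number from compound 1 to compound 3 (0.10 log units; within the scatter) in one case and a 1.4-fold lower number from compound 2 to compound 3 (0.14 log units; within the scatter) in another. The remaining step, a 1.1-fold higher number from compound 1 to compound 2 (0.05 log units; within the scatter) as well, alters the same group through cyclopropyl in place of methoxy on an aromatic carbon. For the measured compounds named here, all three stay within the scatter, although no measured compound carries 2,4-difluorophenyl. No step beyond the scatter is therefore expected in this assay for this exchange.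

The expected change is a 1.1-fold higher number from compound 3 to compound 4 (0.05 log units; within the scatter) and no more than that.

For compound 4 the estimated value is 48 mL/min/kg with an expected range from 29 mL/min/kg to 78 mL/min/kg.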

Compound 4, clearance: 27 mL/min/kg
Beside the measured number, compound 4's estimate is 1.8-fold (0.25 log units) above it, outside the stated range (below it).
By their numbers in this assay, from the lowest: compounds 4, 3, 1 and 2 (each within the scatter of the next, the first and the last beyond it).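

Until now, the aryl groups on the amide-type nitrogen looked interchangeable in this assay, since every step among compounds 1, 2 and 3 stayed within the scatter. Among the compounds shown here, the 2,4-difluorophenyl group gives the first step at this position that clears the scatter, a modest one: a 2.2-fold lower number from compound 2 to compound 4 (0.35 log units; beyond the scatter). That signal is limited to a single comparison, as the other two steps, a 1.6-fold lower number from compound 3 to compound 4 (0.20 log units; within the scatter) and a 2.0-fold lower number from compound 1 to compound 4 (0.30 log units; within the scatter), remain within the scatter, so the data separate compound 4 only from compound 2, and nothing measured here accounts for that difference.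

From the compounds shown here alone, it remains open whether the two fluorines of the 2,4-difluorophenyl group act together or one alone carries the step, which simpler groups such as 4-fluorophenyl or 2-fluorophenyl on the same nitrogen could help to settle. It is also open how this position would respond to a different kind of substituent on the phenyl ring, such as an amine or a carboxylic acid, since all the groups shown here carry only halogen, methoxy or cyclopropyl substituents.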